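Amide versus urea linker in the trifluoromethylphenyl series

A few compounds are considered here, and "the series" means these few. Any claim that something is new, unique, unknown or untested is made for them only; others in the source may bear on it.

In a functional assay on SN12C cells (Homo sapiens) for inhibition, read by sulforhodamine B assay, with a stated time of 48 h, tested at 10 uM (a lower number here means a stronger effect, a higher number a weaker effect of the compound at the concentration tested), compound 3 `COc1cc(Cl)cc(-c2nn(-c3cccc(NC(=O)Nc4cccc(C(F)(F)F)c4)c3)cc2-c2ccncc2)c1` gives 13.9%. Among the three measured compounds this places compound 3 second highest: the nearest number belongs to compound 2 `COc1cc(Cl)cc(-c2nn(-c3cccc(NC(=O)Nc4ccc(Cl)c(C(F)(F)F)c4)c3)cc2-c2ccncc2)c1`, which gives 13.8%, and the furthest to compound 1 `COc1cc(Cl)cc(-c2nn(-c3cccc(NC(=O)c4ccc(Cl)c(Cl)c4)c3)cc2-c2ccncc2)c1`, which gives 69.6%. The step of a number 0.1 percentage points higher from compound 2 to compound 3 (within the scatter) lies within the scatter, whereas a number 55.7 percentage points lower from compound 1 to compound 3 (beyond the scatter) and a number 55.8 percentage points lower from compound 1 to compound 2 (beyond the scatter) are both large.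

Compound 4 `COc1cc(Cl)cc(-c2nn(-c3cccc(NC(=O)c4cccc(C(F)(F)F)c4)c3)cc2-c2ccncc2)c1` differs from compound 3 in one place: 3-(trifluoromethyl)phenyl in place of (3-(trifluoromethyl)phenyl)amino on a carbonyl carbon. This change turns the urea of compound 3 into an amide of the kind present in compound 1. Among the measured compounds shown here, two measured steps bear on it. Each of a number 55.7 percentage points lower from compound 1 to compound 3 (beyond the scatter) and a number 55.8 percentage points lower from compound 1 to compound 2 (beyond the scatter) combines the same urea-for-amide exchange with a change of the aryl substituents, so neither separates the two. The step of a number 0.1 percentage points higher from compound 2 to compound 3 (within the scatter), however, shows that exchanging chloro for hydrogen on the aryl ring left the number within the scatter, which leaves the linker exchange as the more likely carrier of the large steps from compound 1.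

Compound 4 is therefore expected to move back toward compound 1, with an estimated step of a number 38.1 percentage points higher from compound 3 to compound 4 (beyond the scatter) in this assay. The estimate for compound 4 is 52%, expected to fall between 28% and 74%.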

Compound 4, a percentage reported as activity, at one concentration (the size of the read-out at that concentration, not a potency): 65.9%
Estimate against measurement, compound 4: 13.9 percentage points below, within the range that was stated.
By their numbers in this assay, from the lowest: compounds 2 and 3 (each within the scatter of the next); then compounds 4 and 1 (each within the scatter of the next).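

With the 3-(trifluoromethyl)phenyl group held constant, a number 52 percentage points higher from compound 3 to compound 4 (beyond the scatter) isolates the linker in this assay: removing the amino nitrogen from the carbonyl carbon is enough for a large step, which the earlier urea-to-amide steps could not show because each also changed the aryl substituents. The step of a number 52.1 percentage points higher from compound 2 to compound 4 (beyond the scatter) points the same way but again combines the linker exchange with loss of the chloro group, so it adds a second large urea-to-amide comparison rather than a cleaner one. Within the amides, a number 3.7 percentage points lower from compound 1 to compound 4 (within the scatter) separates 3-(trifluoromethyl)phenyl from 3,4-dichlorophenyl by no more than the scatter, so across these four compounds the linker, not the aryl substitution, tracks the large differences, and no compound goes against this.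

On these data alone, whether the amino nitrogen itself or its hydrogen-bond donor carries the step stays open, and an N-methyl urea, a carbamate or a sulfonamide at this position would help to separate the two. The data offer no measured basis for explaining why the linker exchange has this effect.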